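The compounds below may be only part of what the source reports. "The series", "measured", "known", "first", "only" and "open" are said of these compounds alone.

Compound 1 `ClCc1ccccc1Cn1cnc2c(Cl)nc(Cl)nc21` and compound 2 `ClCc1cccc(Cn2cnc3c(Cl)nc(Cl)nc32)c1` are built from the same atoms joined differently; the difference between the two cores is not broken down here. In a functional assay on CCRF-CEM cells (Homo sapiens) for cytotoxicity, read by sulforhodamine B assay, with a stated time of 48 h (on this read-out lower numbers stand for higher toxicity in this test and higher numbers for lower toxicity in this test), compound 1 gives 470 nM. For compound 2 the result in this assay is only a limit, > 100000 nM. Compound 3 `Nc1nc(Cl)c2ncn(Cc3ccccc3CCl)c2n1` arises from compound 1 by amino in place of chloro on an aromatic carbon. For compound 3 the result in this assay is also a limit, > 100000 nM. That change therefore produced an at least 210-fold higher number from compound 1 to compound 3 (2.32 log units; beyond the scatter), ending at the limit of > 100000 nM in this assay, at which 2 of the 3 values shown sit. Compound 4 `Nc1nc(Cl)c2ncn(Cc3cccc(CCl)c3)c2n1` arises from compound 2 by the same change, (amino in place of chloro on an aromatic carbon), at a place described in identical words. Since compound 2 already rests at a limit and the change gave an at least 210-fold higher number from compound 1 to compound 3 (2.32 log units; beyond the scatter), compound 4 is expected to come out at 150000 nM, an estimated step that the limit leaves unreadable from compound 2 to compound 4, most likely itself reported only as a limit.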

Compound 4, concentration lethal to 50% of the cells: > 100000 nM
Compound 4: only a limit was reported; the forecaster's own chance of this, stated with the estimate: 90%; the middle value lies beyond the limit too.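

Among these compounds, compound 2 and compound 4 both sit at a limit, so no step between them can be read: the limit of > 100000 nM in this assay, at which 3 of the 4 values shown sit. On these data alone, whether amino in place of chloro changes the result for compound 2 stays open.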